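The compounds below may be only part of what the source reports. "The series", "measured", "known", "first", "only" and "open" are said of these compounds alone.

Compound 3 `CCOC(=O)/C=C1\C(=O)N(Cc2ccc(OC)cc2)c2ccc(-c3ccc(OC)cc3)cc21` carries an ethoxycarbonyl group on a double bond that hangs off its core. In a functional assay on HepG2 cells (Homo sapiens) for antiproliferative activity, read by MTT assay, with a stated time of 48 h (a lower number here means a stronger inhibitor, a higher number a weaker inhibitor), compound 3 gives 3390 nM. Among the numbers in hand this is the highest; the nearest is compound 1 `COc1ccc(CN2C(=O)C(=O)c3cc(-c4ccc(C(F)(F)F)cc4)ccc32)cc1`, which in this assay gives 820 nM. Compound 2 `COc1ccc(CN2C(=O)C(=O)c3cc(-c4ccncc4)ccc32)cc1` has only a limit in this assay, > 10000 nM, which is the limit of > 10000 nM in this assay, at which 1 of the 3 values shown sits.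

Compound 4 `COc1ccc(CN2C(=O)/C(=C\c3ccc(C(F)(F)F)cc3)c3cc(-c4ccc(OC)cc4)ccc32)cc1` differs from compound 3 in a single place: 4-(trifluoromethyl)phenyl in place of ethoxycarbonyl on a double-bonded chain carbon bound to a double-bonded ring carbon. The new group sits on a double-bonded chain carbon bound to a double-bonded ring carbon.

Going by the values given here, only one measured step exists, an at least 12-fold higher number from compound 1 to compound 2 (1.08 log units; beyond the scatter), and it concerns the aryl group on an aromatic carbon of the core rather than the chain, so it does not bear directly on the change from compound 3 to compound 4. It does show that the compound bearing a 4-(trifluoromethyl)phenyl group, compound 1, gave 820 nM, the lowest plain number seen.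

Without a closer precedent, the step of a 2.3-fold lower number from compound 3 to compound 4 (0.35 log units; beyond the scatter) is expected to be a modest move toward a lower number. The estimate for compound 4 in this assay is 1500 nM, with a range from 400 nM to 6000 nM.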

Compound 4, half-maximal inhibitory concentration: > 10000 nM
Compound 4: a limit, no number; the forecaster's own chance of this, stated with the estimate: 10%; middle value at least 6.6-fold (0.82 log units) away from the limit.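

In this assay, going by these compounds alone, the double-bonded chain carbon bound to a double-bonded ring carbon is the first place on the chain where a change can be read, and it does not tolerate every group: 4-(trifluoromethyl)phenyl in place of ethoxycarbonyl gives an at least 2.9-fold higher number from compound 3 to compound 4 (0.46 log units; beyond the scatter). From the compounds shown here alone, compound 4 has only a limit, > 10000 nM, and not a number, so this step gives a minimum and its full size stays unknown. Compound 4 now shares that limit with compound 2, so the limit has been reached through a change on the chain as well as through a change on an aromatic carbon of the core: the limit of > 10000 nM in this assay, at which 2 of the 4 values shown sit.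

With only two groups shown at this place, one step cannot tell whether the result follows from losing ethoxycarbonyl or from bringing in an aromatic ring with its trifluoromethyl group. A plain phenyl ring, a carboxylic acid or a simple amide on the same chain carbon would help separate these two readings, and each would show whether this place can give a number lower than that of compound 3.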